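Changing the Amide Cap: From Compound 2 to Compound 3

The source may report more compounds than this note shows. Statements on the series, on what has been measured and on what is new or still open speak of the compounds shown alone.

Among the compounds with values here, compound 2 `CN1[C@@H]2c3[nH]c4ccccc4c3C[C@H]1[C@H](C#N)N1[C@@H](CNC(=O)c3cccc4c3CCCC4)c3[nH]c4ccccc4c3C[C@@H]21` shows the higher of the two numbers so far in a functional assay on BGC-823 cells (Homo sapiens) for cytotoxicity, read by MTT assay, with a stated time of 72 h (a higher number here means a weaker inhibitor, a lower number a stronger inhibitor), giving 3540 nM, while compound 1 `CCc1ccc(C(=O)NC[C@H]2c3[nH]c4ccccc4c3C[C@H]3[C@H]4c5[nH]c6ccccc6c5C[C@@H]([C@H](C#N)N23)N4C)cc1` gives 660 nM. Compound 3 `CN1[C@@H]2c3[nH]c4ccccc4c3C[C@H]1[C@H](C#N)N1[C@@H](CNC(=O)/C=C/c3ccccc3)c3[nH]c4ccccc4c3C[C@@H]21` carries 2-phenylethenyl in place of 1,2,3,4-tetrahydronaphthalen-5-yl on a carbonyl carbon. Within the data shown here, no measured step covers this exact change; the only step, a 5.4-fold higher number from compound 1 to compound 2 (0.73 log units; beyond the scatter), shows that swapping the group on this carbonyl carbon shifts the number modestly. Given a 5.4-fold higher number from compound 1 to compound 2 (0.73 log units; beyond the scatter) ran upward on entering the fused ring, a modest lowering is expected on returning to a single aromatic ring, a 2.7-fold lower number from compound 2 to compound 3 (0.44 log units; beyond the scatter). Compound 3 is expected near 1300 nM, within 450 nM to 3800 nM.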

Compound 3, half-maximal inhibitory concentration: 4300 nM
Estimate against measurement, compound 3: 3.3-fold (0.52 log units) below, outside the stated range (above it).
By their numbers in this assay, from the lowest: compound 1; then compounds 2 and 3 (each within the scatter of the next).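

In this assay, the step of a 1.2-fold higher number from compound 2 to compound 3 (0.08 log units; within the scatter) shows that 2-phenylethenyl and 1,2,3,4-tetrahydronaphthalen-5-yl on this carbonyl carbon cannot be told apart, so having a single aromatic ring in the group is not enough to match compound 1. Within the data shown here, the step of a 6.5-fold higher number from compound 1 to compound 3 (0.81 log units; beyond the scatter) leaves 4-ethylphenyl as the one group of the three that stands apart. Nothing measured here explains this difference. Still open, from the compounds shown here alone, is how the number would respond to an amine or a carboxylic acid on the aromatic ring of this group, or to a longer chain in place of the ethyl of 4-ethylphenyl.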